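Ring size on the thiourea nitrogen and cell toxicity

A few compounds are considered here, and "the series" means these few. Any claim that something is new, unique, unknown or untested is made for them only; others in the source may bear on it.

Compound 1 `CC(C)NC(=S)N1CC(C)C(c2ccccc2)=N1`: in an ADME assay on KB cells (Homo sapiens) for cytotoxicity, read by MTT assay, with a stated time of 44 h (a higher number here means a weaker inhibitor, a lower number a stronger inhibitor), compound 1 gives > 100000 nM, a limit of the assay.
Compound 2 `CC(C)CNC(=S)N1CC(C)C(c2ccccc2)=N1`: compound 2 gives > 100000 nM, a limit of the assay.
Compound 3 `CC1CN(C(=S)NC2CCCC2)N=C1c1ccccc1`: compound 3 gives > 100000 nM, a limit of the assay.

Compound 3 stands at a limit in this assay, so no number is known for it; the same is true of every value shown, as the limit of > 100000 nM in this assay, at which 3 of the 3 values shown sit, makes plain. The steps among the measured compounds are therefore not readable: a step that the two limits leave unreadable from compound 1 to compound 2, a step that the two limits leave unreadable from compound 1 to compound 3 and a step that the two limits leave unreadable from compound 2 to compound 3 all stay hidden behind the limit. The change to compound 4 `CC1CN(C(=S)NC2CCCCC2)N=C1c1ccccc1` is cyclohexyl in place of cyclopentyl on an amide-type nitrogen. For the measured compounds named here, the steps that bear on it, each one ring or branch swapped for another on the same nitrogen, gave no readable size, so no direction can be drawn from them. Compound 4 is expected to behave like compound 3, with a step that the limit leaves unreadable from compound 3 to compound 4 that is expected to stay within the scatter. Compound 4 is estimated at 150000 nM, with a range from 50000 nM to 500000 nM, most likely reported again only as a limit.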

Compound 4, half-maximal inhibitory concentration: > 100000 nM
Compound 4 gave a limit, no number; the forecaster's own chance of this, stated with the estimate: 85%; the middle value is on the limit's open side.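

In this assay compound 4 gives > 100000 nM and this is a limit, not a number, so no step linking it to compound 1, compound 2 or compound 3 can be read: the limit of > 100000 nM in this assay, at which 4 of the 4 values shown sit.

The compounds shown leave open how strongly any of them acts on these cells, and whether isopropyl, isobutyl, cyclopentyl or cyclohexyl on the amide-type nitrogen makes any difference.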